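Changing the sulfonamide ring: a clearance forecast for compound 3

The source may hold more compounds than are shown below. What is called first, only, known or untested is meant among the compounds shown, and "the series" means these compounds.

Of the compounds shown here, two that share one core have been measured in an ADME assay on liver (Homo sapiens) for metabolic stability, read by LC-MS, using microsomes and NADPH, with a stated time of 40 min, tested at 1 uM; on this read-out higher numbers stand for fast clearance and lower numbers for slow clearance. In this test, compound 1 (`COc1cc(C(F)(F)F)ccc1-c1cccc2cc(S(=O)(=O)Nc3ncns3)ccc12`) gives 15 mL.min-1.g-1 and compound 2 (`COc1cc(C(F)(F)F)ccc1-c1cccc2cc(S(=O)(=O)Nc3ncccn3)ccc12`) gives 17 mL.min-1.g-1, so compound 2 stands level with compound 1 within the scatter.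

Compound 3 (`COc1cc(C(F)(F)F)ccc1-c1cccc2cc(S(=O)(=O)Nc3cscn3)ccc12`) has not yet been measured. It carries 1,3-thiazol-4-yl in place of pyrimidin-2-yl on a sulfonamide nitrogen.

Going by the values given here, only one measured step bears on this change. It also exchanges the ring on the sulfonamide nitrogen, placing pyrimidin-2-yl where compound 1 has 1,2,4-thiadiazol-5-yl, and it amounts to a 1.1-fold higher number from compound 1 to compound 2 (0.05 log units; within the scatter). Among the compounds with values here, this is thin evidence, as no measured compound yet carries 1,3-thiazol-4-yl. On that single step, no change beyond the scatter is expected in this assay, and no firm direction can be given. The estimated step is a 1.1-fold higher number from compound 2 to compound 3 (0.05 log units; within the scatter). Compound 3 is expected to give about 19 mL.min-1.g-1, with an estimated range of 9 mL.min-1.g-1 to 38 mL.min-1.g-1.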

Compound 3, intrinsic clearance in microsomes: < 14 mL.min-1.g-1
Compound 3 was reported as a limit; the forecaster's own chance of this, stated with the estimate: 3%; middle value at least 1.3-fold (0.13 log units) away from the limit.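

In this assay, compound 3 is reported as a limit and not as a number, the only such reading among the three compounds: the limit of < 14 mL.min-1.g-1 in this assay, at which 1 of the 3 values shown sits.

Set against the pyrimidin-2-yl ring, the result reads as an at least 1.2-fold lower number from compound 2 to compound 3 (0.08 log units; that floor lies within the scatter), and set against the 1,2,4-thiadiazol-5-yl ring, it reads as an at least 1.0-fold lower number from compound 1 to compound 3 (0.02 log units; that floor lies within the scatter). Both figures are floors and not sizes, so the true gaps may be wider, but neither floor by itself passes the scatter. What this adds is that a third ring on the sulfonamide nitrogen, 1,3-thiazol-4-yl, brings the read-out to the limit of the assay, which neither earlier ring did, and gives no sign of a rise in clearance.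

From the compounds shown here alone, how far compound 3 really lies past its limit stays open, and so does whether a real gap separates it from compound 1 or compound 2. Also open, going by these compounds, is how this position would respond to a ring such as pyridin-2-yl or 1,3-thiazol-2-yl, or to a non-aromatic group such as a simple methyl or a longer alkyl chain on the same nitrogen.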